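The source may report more compounds than this note shows. Statements on the series, on what has been measured and on what is new or still open speak of the compounds shown alone.

Compound 2 `C#Cc1cn([C@@H]2O[C@H](CO)[C@@H](O)[C@H]2O)c2ncnc(C)c12` is the anchor of the series; in a functional assay on CEM-DNR-bulk cells (Homo sapiens), read by MTT assay, with a stated time of 72 h (a higher number here means a weaker inhibitor, a lower number a stronger inhibitor), compound 2 gives 160 nM. Compound 1 `Cc1ncnc2c1c(I)cn2[C@@H]1O[C@H](CO)[C@@H](O)[C@H]1O` gives 12600 nM in this assay, and the change iodo in place of ethynyl on an aromatic carbon made a step of a 79-fold higher number from compound 2 to compound 1 (1.90 log units; beyond the scatter). Compound 3 `C#Cc1cn([C@@H]2O[C@H](CO)[C@@H](O)[C@H]2O)c2ncnc(OC)c12` gives 3490 nM; the cores of compound 2 and compound 3 differ by methoxy in place of methyl on an aromatic carbon, a step of a 22-fold higher number from compound 2 to compound 3 (1.34 log units; beyond the scatter). Compound 4 `COc1ncnc2c1c(I)cn2[C@@H]1O[C@H](CO)[C@@H](O)[C@H]1O` remains to be measured in this assay. It differs from compound 3 by iodo in place of ethynyl on an aromatic carbon, the same change, at the same place, as from compound 2 to compound 1. The step from compound 3 to compound 4 is expected to be of similar size, estimated at a 34-fold higher number from compound 3 to compound 4 (1.54 log units; beyond the scatter), because that change gave a 79-fold higher number from compound 2 to compound 1 (1.90 log units; beyond the scatter) on the other core. For compound 4 in this assay a value near 120000 nM is therefore expected, between 30000 nM and 500000 nM.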

Compound 4, half-maximal inhibitory concentration: > 20000 nM
Compound 4: only a limit was reported; the forecaster's own chance of this, stated with the estimate: 50%; the middle value lies beyond the limit too.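

In this assay compound 4 carries only a limit, not a number: > 20000 nM. Iodo in place of ethynyl gives an at least 5.7-fold higher number from compound 3 to compound 4 (0.75 log units; beyond the scatter), so the direction of the change carries over to the core of compound 3, but the size of the step on that core is not shown: the same change on two cores in this assay, a 79-fold higher number (1.90 log units; beyond the scatter) from compound 2 to compound 1 and an at least 5.7-fold higher number (0.75 log units; beyond the scatter) from compound 3 to compound 4; the limit leaves it open whether they differ Methoxy in place of methyl gives an at least 1.5-fold higher number from compound 1 to compound 4 (0.20 log units; that floor lies within the scatter), and this floor alone does not show that the change carries over to the iodo compounds: the same change on two cores in this assay, a 22-fold higher number (1.34 log units; beyond the scatter) from compound 2 to compound 3 and an at least 1.5-fold higher number (0.20 log units; that floor lies within the scatter) from compound 1 to compound 4; the limit leaves it open whether they differ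

Still open, as far as these compounds go, is how far past its limit compound 4 lies. Also open, from the compounds shown here alone, is how an amine or a longer chain in place of ethynyl on this aromatic carbon would read on either core.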